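This account rests on a few compounds, and the source may have more. Where it says the series, first, only, none or still open, it means among the compounds named here.

Working notes on the ester series. Compound 1 `CCCCc1nc(C)c(CC(=O)OC)c(=O)n1Cc1ccc(-c2ccccc2-c2noc(=O)[nH]2)cc1` carries a methyl ester; in an ADME assay on microsomes from liver (Homo sapiens) for metabolic stability, with a stated time of 30 min (on this read-out higher numbers stand for a more stable compound and lower numbers for a less stable compound), compound 1 gives 69.6%. Compound 2 `CCCCc1nc(C)c(CC(=O)OC2CCCCC2)c(=O)n1Cc1ccc(-c2ccccc2-c2noc(=O)[nH]2)cc1` carries a cyclohexyl ester, and in this assay compound 2 gives 3.9%. Compound 3 `CCCCc1nc(C)c(CC(=O)OCC2CC2)c(=O)n1Cc1ccc(-c2ccccc2-c2noc(=O)[nH]2)cc1` carries a cyclopropylmethyl ester; in this assay compound 3 gives 20%, second highest of the three, beneath compound 1 and above compound 2. For the measured compounds named here, the steps so far: a number 65.7 percentage points lower from compound 1 to compound 2 (beyond the scatter); a number 49.6 percentage points lower from compound 1 to compound 3 (beyond the scatter); a number 16.1 percentage points higher from compound 2 to compound 3 (beyond the scatter).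

Compound 4 `CCCCc1nc(C)c(CC(=O)OCC2CCCCC2)c(=O)n1Cc1ccc(-c2ccccc2-c2noc(=O)[nH]2)cc1` is not yet measured. Its change from compound 3: cyclohexyl in place of cyclopropyl on a saturated chain carbon bound to an oxygen next to a carbonyl group. All three steps bear on it. Both steps that enlarged the group on the oxygen next to a carbonyl group lowered the number by a large amount, and the step that replaced cyclohexyl with cyclopropylmethyl raised it only modestly. Enlarging cyclopropyl to cyclohexyl is therefore expected to lower the number beyond the scatter, toward the level of compound 2. The expected step is a number 13 percentage points lower from compound 3 to compound 4 (beyond the scatter). Compound 4 is estimated at 7%, in the range 2% to 18%.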

Compound 4, percent of the compound remaining: 11.5%
Beside the measured number, compound 4's estimate is 4.5 percentage points below it; measured number inside the range.
By their numbers in this assay, from the lowest: compounds 2, 4 and 3 (each within the scatter of the next, the first and the last beyond it); then compound 1.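

On a saturated chain carbon bound to an oxygen next to a carbonyl group, the change from cyclopropyl to cyclohexyl gives a number 8.5 percentage points lower from compound 3 to compound 4 (within the scatter), so in this assay this difference in ring size is not resolved at this position. The same holds for cyclohexylmethyl in place of cyclohexyl on the oxygen next to a carbonyl group, with a number 7.6 percentage points higher from compound 2 to compound 4 (within the scatter), so compound 4 cannot be separated from either neighbouring ester. The other comparison, a number 58.1 percentage points lower from compound 1 to compound 4 (beyond the scatter), shows that the cyclohexylmethyl ester also stands well apart from the methyl ester, as the cyclohexyl and cyclopropylmethyl esters do.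

Open, on these data alone, is where between methyl and these larger esters the number falls, and how an ethyl ester, an amide or the free carboxylic acid would read in this assay. Nothing at hand gives a cause for any of these steps.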